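Fluorine on the benzamide, without a starting number

A few compounds are considered here, and "the series" means these few. Any claim that something is new, unique, unknown or untested is made for them only; others in the source may bear on it.

compound 1 `CCOC(=O)c1sc(-c2cccc(NC(=O)c3cccc(F)c3)c2)nc1Nc1ccc(N2CCN(C)CC2)cc1`: 21200 nM
compound 2 `CN1CCN(c2ccc(Nc3nc(-c4cccc(NC(=O)c5ccccc5)c4)sc3C(=O)O)cc2)CC1`: "not determined" (no result reported)

Going by the values given here, in a functional assay on Raji cells (Homo sapiens) for antiproliferative activity, read by CCK-8 assay, with a stated time of 72 h (on this read-out lower numbers stand for stronger inhibition and higher numbers for weaker inhibition), compound 1 gives 21200 nM, the only number this set holds. Compound 2 went through the same work, but in this assay compound 2 gives "not determined" (no result reported), so it stands nowhere on the numbers shown and cannot be ranked against anything. Compound 3 `CN1CCN(c2ccc(Nc3nc(-c4cccc(NC(=O)c5cccc(F)c5)c4)sc3C(=O)O)cc2)CC1` follows from compound 2 by one change: fluoro in place of hydrogen on an aromatic carbon, meta to a large group, which read one bond further out is benzamido to ((3-fluorophenyl)carbonyl)amino. Among the compounds with values here, no measured pair of this kind exists, so no size can be read off for the step in this assay; an expectation of nothing beyond the scatter, in either direction, is as defensible as any. Within the data shown here, the sole anchor for scale is compound 1, whose weak figure of 21200 nM is the only measurement available. Compound 3 is accordingly estimated at 20000 nM, with a range from 5000 nM to 80000 nM.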

Compound 3, half-maximal inhibitory concentration: 35100 nM
Estimate against measurement, compound 3: 1.8-fold (0.24 log units) below; low and high end bracket the measured number.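

In this assay the set now holds its first readable pair: with the 3-fluorophenyl held in place, hydrogen stands for ethyl on the oxygen next to a carbonyl group, which gives a 1.7-fold higher number from compound 1 to compound 3 (0.22 log units; within the scatter). At this oxygen, then, the ethyl ester and the carboxylic acid are not told apart on this read-out, and the fluorinated benzamide gives no sign of stronger inhibition in either form. Nothing measured here explains this result.

From the compounds shown here alone, the step from compound 2 to compound 3 cannot be read, as compound 2 has no number, so what fluoro itself does at this place remains unknown. Also open, going by these compounds, is how a chloro or methoxy group on the same phenyl, or a primary amide in place of the carboxylic acid, would read.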